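This account rests on a few compounds, and the source may have more. Where it says the series, first, only, none or still open, it means among the compounds named here.

Measured so far:
- Compound 1 `CNC(=O)c1cc(C(=O)NCCO)cn(Cc2ccccc2)c1=O`: >= 140 ug/mL (a limit of the assay, not a number)
- Compound 2 `CNC(=O)c1cc(C(=O)NC2CCC2)cn(Cc2ccccc2)c1=O`: 28 ug/mL

Among the measured compounds shown here, only two compounds have been measured in a physicochemical assay for solubility (a higher number here means a more soluble compound, a lower number a less soluble compound), and they share the same core. For the measured compounds named here, compound 2, at 28 ug/mL, holds the only true number so far. The other result is the limit for compound 1, >= 140 ug/mL.

The next compound, compound 3 `CNC(=O)c1cc(C(=O)NCCOC)cn(Cc2ccccc2)c1=O`, has 2-methoxyethyl in place of cyclobutyl on an amide-type nitrogen. Going by the values given here, one measured step bears on this change: an at least 5.0-fold lower number from compound 1 to compound 2 (0.69 log units; beyond the scatter). There, cyclobutyl replaced 2-hydroxyethyl at the same kind of nitrogen, so the change now in question runs roughly the opposite way. The entering group is 2-methoxyethyl rather than 2-hydroxyethyl, however, so that step is only a partial guide.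

A rise in this assay beyond the scatter therefore seems likely, with a single step as its only support. The expected move is a 3.9-fold higher number from compound 2 to compound 3 (0.59 log units; beyond the scatter). For compound 3 the estimated value is 110 ug/mL, with an expected range from 50 ug/mL to 200 ug/mL.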

Compound 3, solubility: >= 164 ug/mL
Compound 3: a limit, no number; the forecaster's own chance of this, stated with the estimate: 35%; middle value at least 1.4-fold (0.17 log units) away from the limit.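

On this amide-type nitrogen, this assay now shows an at least 5.8-fold higher number from compound 2 to compound 3 (0.76 log units; beyond the scatter) and so a second group, not only 2-hydroxyethyl, stands clearly apart from cyclobutyl at this position. Cyclobutyl and 2-methoxyethyl have the same count of heavy atoms, so this step does not go with a change in that count; it goes with a ring of carbon only giving way to an open chain that holds one oxygen. Compound 3 gives a limit of the assay, not a number: the limit of >= 164 ug/mL in this assay, at which 1 of the 3 values shown sits.

From the compounds shown here alone, compound 1 also gives only a limit, so the step to compound 3, methyl in place of hydrogen on an oxygen, cannot be read, and it stays open how far apart these two compounds lie, if at all. Also open, going by these compounds, is whether the oxygen or the open chain goes with the step, which a plain butyl chain or a ring holding oxygen could help to separate, and whether an amine or a carboxylic acid on the same chain would give a similar result.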